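Amide nitrogen methylation: notes toward compound 4

The source may hold more compounds than are shown below. What is called first, only, known or untested is meant among the compounds shown, and "the series" means these compounds.

Measured in an assay on isolated protein for inhibition of 2-Hydroxyacid oxidase 2 (Homo sapiens), tested at 10 uM; a higher number here means a stronger effect of the compound at the concentration tested, a lower number a weaker effect:
compound 1, `Cc1n[nH]c(C(N)=O)c1Cc1cccc(-c2ccc(F)cc2)c1`, gives 14%
compound 2, `Cc1n[nH]c(C(=O)O)c1Cc1cccc(C(N)=O)c1`, gives 8%
compound 3, `Cc1nn(C)c(C(=O)O)c1Cc1cccc(-c2ccc(F)cc2)c1`, gives 3%

Compound 1 has the highest of the three numbers in this assay. Compound 2 sits within the usual scatter of it, so the two cannot be ordered. Compound 3 lies beyond the scatter below compound 1, but as the two differ in more than one place, nothing can be assigned to a single change. All three numbers are low for a single-concentration read-out.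

Compound 4, `CNC(=O)c1[nH]nc(C)c1Cc1cccc(-c2ccc(F)cc2)c1`, is not yet measured. It differs from compound 1 by methyl in place of hydrogen on an amide-type nitrogen. Within the data shown here, no pair among the measured compounds shows this change, so there is no step to lean on. With nothing beyond the other measured values to go by, the expectation is a step in this assay for a number 3 percentage points lower from compound 1 to compound 4 (within the scatter) that stays within the scatter, with a slight lean downward given how low the whole series already sits. Compound 4 is estimated to give 11% in this assay, with a range from 0% to 24%.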

Compound 4, a percentage reported as inhibition, at one concentration (the size of the read-out at that concentration, not a potency): 19%
Compound 4: middle estimate off by 8 percentage points, on the low side, within the range that was stated.
By their numbers in this assay, from the lowest: compounds 3, 2, 1 and 4 (each within the scatter of the next, the first and the last beyond it).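

In this assay, among these compounds, compounds 1 and 4 form the first pair that differs in one place, and the step reads a number 5 percentage points higher from compound 1 to compound 4 (within the scatter). Methyl in place of the amide hydrogen therefore produces no change that can be told from the scatter, so this single pair gives no sign that this nitrogen must carry the amide hydrogen for the read-out seen with compound 1, nor that methyl here brings a real gain. With compound 4 at 19%, the read-out also remains low for a single concentration, and nothing at hand bears on why the step is this size.

The compounds shown leave open whether an ethyl group, a longer chain, a second methyl or a hydroxyethyl group on the same nitrogen would move the read-out beyond the scatter from compound 1. They also leave open whether a methyl on this nitrogen would give a comparable step when the amide is paired with a different group in place of the 4-fluorophenyl, such as a pyridine or a cyclohexyl ring.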